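Large ring replacing methyl on the shared core

The compounds below may be only part of what the source reports. "The series", "measured", "known", "first", "only" and "open" are said of these compounds alone.

In a functional assay on THP-1 cells (Homo sapiens) for inhibition, read by ELISA, with stated times of 1 h and 18 h (on this read-out higher numbers stand for weaker inhibition and lower numbers for stronger inhibition), compound 1 `Cc1cnc(Nc2cccc(C(=O)N3CCCC3)c2)nc1N[C@H]1[C@@H](C(N)=O)[C@@H]2C=C[C@H]1C2` gives 100 nM and compound 2 `NC(=O)[C@@H]1[C@H](Nc2nc(Nc3cccc(C(=O)N4CCCC4)c3)ncc2C2CC2)[C@H]2C=C[C@@H]1C2` gives 90 nM, the two lying within the scatter of each other. Compound 3 `NC(=O)[C@@H]1[C@H](Nc2nc(Nc3cccc(C(=O)N4CCCC4)c3)ncc2-c2ccncc2)[C@H]2C=C[C@@H]1C2` gives the highest number of the three, 320 nM.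

Compound 4 `NC(=O)[C@@H]1[C@H](Nc2nc(Nc3cccc(C(=O)N4CCCC4)c3)ncc2-c2cccc(F)c2)[C@H]2C=C[C@@H]1C2` differs from compound 1 as follows: 3-fluorophenyl in place of methyl on an aromatic carbon. In words, this is 3-fluorophenyl in place of methyl on an aromatic carbon.

For the measured compounds named here, two measured steps bear on this. Cyclopropyl in place of methyl gave a 1.1-fold lower number from compound 1 to compound 2 (0.05 log units; within the scatter), while pyridin-4-yl, the only aromatic ring measured at this place, gave a 3.2-fold higher number from compound 1 to compound 3 (0.51 log units; beyond the scatter). The second is the closer precedent, so a modest rise in this assay is expected.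

The expected change is a 2.0-fold higher number from compound 1 to compound 4 (0.30 log units; within the scatter). For compound 4, the estimated value is 200 nM, with an expected range of 70 nM to 600 nM.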

Compound 4, half-maximal inhibitory concentration: 870 nM
The estimate for compound 4 lay 4.4-fold (0.64 log units) below the measured number; the whole stated range lies below it.
By their numbers in this assay, from the lowest: compounds 2 and 1 (each within the scatter of the next); then compound 3; then compound 4.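

In this assay, for the compounds shown here, 3-fluorophenyl is the costliest replacement at this position so far, well beyond the scatter against methyl (an 8.7-fold higher number from compound 1 to compound 4 (0.94 log units; beyond the scatter)) and cyclopropyl (a 9.7-fold higher number from compound 2 to compound 4 (0.99 log units; beyond the scatter)). The two aromatic rings also separate (a 2.7-fold higher number from compound 3 to compound 4 (0.43 log units; beyond the scatter)), so pyridin-4-yl does not speak for every aromatic ring here. No data shown explain this separation.

Whether the fluorine or the phenyl ring itself carries the loss stays open, as unsubstituted phenyl does not appear among these compounds. Nor do these compounds show how 4-fluorophenyl or a phenyl ring bearing an amine would behave.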